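The compounds below may be only part of what the source reports. "The series", "measured", "known", "first", "only" and "open" are said of these compounds alone.

Measured in a functional assay on cells (Panel prostate (Carcinoma cell lines), Homo sapiens) for inhibition; a lower number here means a stronger inhibitor of growth, a higher number a weaker inhibitor of growth:

- Compound 1 `Cc1cc(C)c2c(O)cc(-c3cccc(Cl)c3)nc2n1`: 3090 nM
- Compound 2 `Cc1cnc2[nH]c(-c3cccc(Cl)c3)cc(=O)c2c1`: > 100000 nM

Of these two results, only compound 1 gives a number. Compound 2 reads > 100000 nM, which is a limit of this assay and not a number. Compound 3 `Cc1cnc2[nH]c(-c3cccc(F)c3)cc(=O)c2c1` keeps the rest of compound 2 and has fluoro in place of chloro on an aromatic carbon, on a six-membered aromatic ring of carbon only, meta to a large group (fluoro in place of chloro on an aromatic carbon). For the measured compounds named here, no measured pair isolates this change, so its size can only be judged from the change itself. This single exchange is expected to give no step beyond the scatter, and no direction is favoured. The estimated step is a number no higher from compound 2 to compound 3 (the limit leaves the size open). Compound 3 is expected to stay near the limit, with an estimated value of 100000 nM and a range of 30000 nM to 100000 nM.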

Compound 3, concentration for total growth inhibition: 692 nM
Compound 3: middle estimate off by 140-fold (2.16 log units), on the high side; measured number below the stated range.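

In this assay the exchange of chloro for fluoro on an aromatic carbon, meta to a large group, gives an at least 140-fold lower number from compound 2 to compound 3 (2.15 log units; beyond the scatter) and so shows that this one place, with a change of one heavy atom, can separate a compound without a number from a compound with one. Compound 2 reads > 100000 nM and this is a limit of the assay, not a number. On these data alone, the true size of the step stays unknown because it starts from that limit: the limit of > 100000 nM in this assay, at which 1 of the 3 values shown sits.

As far as these compounds go, how hydrogen, a methoxy group or an amine at this place would read remains open. Also open, from the compounds shown here alone, is whether the same exchange of chloro for fluoro would count for as much on the core of compound 1.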